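The source may report more compounds than this note shows. Statements on the series, on what has been measured and on what is new or still open speak of the compounds shown alone.

Measured compounds:

Compound 1, `Nc1nc(N)c2c(-c3cc4ccccc4o3)cn([C@@H]3O[C@H](CO)[C@@H](O)[C@H]3O)c2n1`. In an ADME assay on BJ cells (Homo sapiens), read by MTT assay, with a stated time of 72 h (a lower number here means a stronger inhibitor, a higher number a weaker inhibitor), compound 1 gives > 100000 nM; this is a limit of the assay, not a number.

Compound 2, `C#Cc1cn([C@@H]2O[C@H](CO)[C@@H](O)[C@H]2O)c2ncnc(OC)c12`. In this assay compound 2 gives 98400 nM.

Compound 2 therefore holds the only number shown in this assay; the one other value sits at a limit, (the limit of > 100000 nM in this assay, at which 1 of the 2 values shown sits). Both results point to weak inhibition of the growth of these cells over the stated period, but only compound 2 provides a number to build on.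

Compound 3, `COc1ncnc2c1c(-c1ccco1)cn2[C@@H]1O[C@H](CO)[C@@H](O)[C@H]1O`, has not yet been measured in this assay. Its structure is that of compound 2 with one change: furan-2-yl in place of ethynyl on an aromatic carbon. Within the data shown here, no step between two measured compounds is available here, so the data give no direction for such a change. The expectation for the step from compound 2 to compound 3 in this assay is therefore a 1.2-fold lower number from compound 2 to compound 3 (0.06 log units; within the scatter), a step not beyond the usual scatter, with a real chance that the assay again reports only a limit. Compound 3 is accordingly estimated at 85000 nM, expected to lie between 30000 nM and 200000 nM.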

Compound 3, half-maximal inhibitory concentration: 430 nM
Beside the measured number, compound 3's estimate is 200-fold (2.30 log units) above it; measured number outside the range, below it.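

The result shows that the group on this aromatic carbon is far from a minor detail of the structure. In this assay, putting furan-2-yl in place of ethynyl gives a 230-fold lower number from compound 2 to compound 3 (2.36 log units; beyond the scatter), so this single change separates a very weak inhibitor of the growth of these cells from a much stronger one. This is the first step in the series that can be read between two measured compounds, and it shows that the position can respond strongly to what is placed on it, although nothing shown here explains why this change has so large an effect.

The compounds shown leave open whether the drop in the number comes from having a five-membered aromatic ring at this carbon or depends on the ring oxygen of the furan-2-yl group, and a thiophen-2-yl group on the same carbon would test that directly. Also open, from the compounds shown here alone, is how a phenyl group, with its six-membered ring, or a small methyl group with no ring at all would behave at this position on the same core.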